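Fluoro for trifluoromethyl: notes on compound 4

The source may report more compounds than this note shows. Statements on the series, on what has been measured and on what is new or still open speak of the compounds shown alone.

Measured in a functional assay on cells (Cancer cell lines, Homo sapiens) for inhibition; on this read-out higher numbers stand for weaker inhibition of growth and lower numbers for stronger inhibition of growth:
- compound 1 `Cc1cc(-c2nc3c(F)cccc3s2)ccc1N`: no result reported
- compound 2 `Cc1cc(-c2nc3cc(F)c(F)cc3s2)ccc1N`: < 10 nM (a limit of the assay, not a number)
- compound 3 `Nc1ccc(-c2nc3ccccc3s2)cc1C(F)(F)F`: 13200 nM

Among the measured compounds shown here, compound 3 gives 13200 nM, the only true number in this small set. For compound 2 the assay reports only a limit, < 10 nM. Compound 1 has no result, so it offers no comparison.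

The next compound to be tested is compound 4 `Nc1ccc(-c2nc3ccccc3s2)cc1F`. It carries fluoro in place of trifluoromethyl on an aromatic carbon, ortho to an amino group: fluoro in place of trifluoromethyl on an aromatic carbon.

For the measured compounds named here, no step between measured compounds is available, so the expectation rests on little. Compound 3 at 13200 nM leaves wide room toward stronger inhibition of growth in this assay, and compound 2 shows that strong inhibition occurs within this small set. A step toward stronger inhibition, well beyond the scatter, is therefore expected, although its size is uncertain. The expected change is a 44-fold lower number from compound 3 to compound 4 (1.64 log units; beyond the scatter). For compound 4 the estimated value is 300 nM, with an expected range from 15 nM to 6000 nM.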

Compound 4, concentration for 50% growth inhibition: < 10 nM
Compound 4: a limit, no number (the forecaster's own chance of this, stated with the estimate: 20%); middle value at least 30-fold (1.47 log units) from the limit.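

In this assay, exchanging trifluoromethyl for fluoro on this aromatic carbon, ortho to an amino group, gives an at least 1300-fold lower number from compound 3 to compound 4 (3.12 log units; beyond the scatter). Compound 4 reads < 10 nM, which is a limit of the assay and not a number. The earlier compounds offered no step at all, and this first one shows that, on the core shared by compound 3 and compound 4, the single group at this position can carry the read-out from weak inhibition of growth to the strong end of what the assay reports, with the true size of the change hidden at that end: the limit of < 10 nM in this assay, at which 2 of the 4 values shown sit.

Whether the gain comes from fluoro itself or from the loss of trifluoromethyl remains open, since the compounds shown include neither hydrogen nor any other group at this position on this core, such as chloro, methoxy, a nitrile or a longer chain. With compound 4 at the limit, any further strengthening from such groups could not be ranked in this assay, so only a weaker result would separate them from fluoro.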